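Ethyl ester versus free acid on a shared pyrazole-free core

A few compounds are considered here, and "the series" means these few. Any claim that something is new, unique, unknown or untested is made for them only; others in the source may bear on it.

Compound 1 `C=CC(=O)Nc1cccc(Cn2nc(-c3ccc(Oc4ccccc4)cc3)cc2C(=O)OCC)c1`: 8600 nM
Compound 2 `C/C=C/C(=O)Nc1cccc(Cn2nc(-c3ccc(Oc4ccccc4)cc3)cc2C(=O)O)c1`: 31600 nM

In a functional assay on Maver1 cells (Homo sapiens) for inhibition, read by luminescence and CellTiter-Glo, with a stated time of 72 h (a lower number here means a stronger inhibitor, a higher number a weaker inhibitor), compound 1 gives 8600 nM, and compound 2 gives 31600 nM. Compound 2 has the highest of the two numbers; the nearest is compound 1, whose number is lower by a gap beyond the scatter. Compound 3 `C/C=C/C(=O)Nc1cccc(Cn2nc(-c3ccc(Oc4ccccc4)cc3)cc2C(=O)OCC)c1` differs from compound 2 by one change: ethyl in place of hydrogen on an oxygen next to a carbonyl group. For the measured compounds named here, no measured pair shows this change on its own, so the size of the step is not known; a step downward in this assay, beyond the scatter, is expected, since compound 1, which carries the ethyl ester, gives 8600 nM. Compound 3 is estimated at 12000 nM, ranging from 4000 nM to 40000 nM, a step of a 2.6-fold lower number from compound 2 to compound 3 (0.42 log units; beyond the scatter).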

Compound 3, half-maximal inhibitory concentration: 14200 nM
Beside the measured number, compound 3's estimate is 1.2-fold (0.07 log units) below it, within the range that was stated.
By their numbers in this assay, from the lowest: compounds 1 and 3 (each within the scatter of the next); then compound 2.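

In this assay the change from carboxy to ethoxycarbonyl now stands on its own, and it gives a 2.2-fold lower number from compound 2 to compound 3 (0.35 log units; beyond the scatter), a modest step beyond the scatter. Prop-1-en-1-yl in place of vinyl on a carbonyl carbon gives a 1.7-fold higher number from compound 1 to compound 3 (0.22 log units; within the scatter), which lies within the scatter and so separates neither compound from the other. No supporting measurement explains either step. The compounds shown leave open how a longer chain than ethyl on this oxygen, or a primary amide in place of the ester, would read in this assay.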